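The source may hold more compounds than are shown below. What is called first, only, known or untested is meant among the compounds shown, and "the series" means these compounds.

Measured compounds:

Compound 1, `CCNC(=O)C1=C(C)NC(=O)NC1c1ccoc1`, gives 2% in an assay on membranes from HEK293 cells for displacement of a labelled ligand from adenosine receptor A2b (Homo sapiens), read by scintillation counting, with a stated time of 30 min, tested at 1 uM; a higher number here means more inhibition at the concentration tested (going by the name of the read-out), a lower number less inhibition.
Compound 2, `CC1=C(C(=O)NC(C)C)C(c2ccoc2)NC(=O)N1`, gives 3% in this assay.
Compound 3, `CCNC(=O)C1=C(C)NC(=O)NC1c1cccs1`, gives 1% in this assay.

Compound 4, `CC1=C(C(=O)NC(C)C)C(c2cccs2)NC(=O)N1`, has not yet been measured in this assay. It differs from compound 3 by methyl in place of hydrogen on a saturated chain carbon bound to an amide-type nitrogen and a saturated chain carbon. The same change has already been made once among the measured compounds, from compound 1 to compound 2, where it reads (methyl in place of hydrogen on a saturated chain carbon bound to an amide-type nitrogen and a saturated chain carbon); in this assay that step was a number 1 percentage points higher from compound 1 to compound 2 (within the scatter). The two places are the same word for word, so the change from compound 3 to compound 4 is the same change on a different core. The cores differ by thiophen-2-yl in place of furan-3-yl on a saturated ring carbon, and that change in this assay gave a number 1 percentage points lower from compound 1 to compound 3 (within the scatter). All three measured values sit within the scatter of one another, and none of the steps between them rises above it.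

For the measured compounds named here, because the only earlier instance of this change gave a number 1 percentage points higher from compound 1 to compound 2 (within the scatter), and because the core change itself gave a number 1 percentage points lower from compound 1 to compound 3 (within the scatter), compound 4 is expected to stay in the same region as its neighbours, with an expected step of a number 1 percentage points higher from compound 3 to compound 4 (within the scatter). Compound 4 is therefore estimated at 2% in this assay, with an expected range from -5% to 10%.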

Compound 4, a percentage reported as inhibition, at one concentration (the size of the read-out at that concentration, not a potency): 40%
Estimate against measurement, compound 4: 38 percentage points below, and the stated range ends below it.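

With the thiophen-2-yl group on the core, the change from ethylcarbamoyl to isopropylcarbamoyl gave a number 39 percentage points higher from compound 3 to compound 4 (beyond the scatter) in this assay, and this step did not carry over from the core of compound 1: the same change on two cores in this assay, a number 1 percentage points higher (within the scatter) from compound 1 to compound 2 and a number 39 percentage points higher (beyond the scatter) from compound 3 to compound 4, 38 percentage points apart, beyond the scatter of two such steps. Read the other way, thiophen-2-yl in place of furan-3-yl gave a number 37 percentage points higher from compound 2 to compound 4 (beyond the scatter), and this step likewise differs from the same ring change made on the ethylcarbamoyl compounds: the same change on two cores in this assay, a number 1 percentage points lower (within the scatter) from compound 1 to compound 3 and a number 37 percentage points higher (beyond the scatter) from compound 2 to compound 4, 38 percentage points apart, beyond the scatter of two such steps. Within these four compounds, then, neither change can be carried over on its own, since the large rise appears only where isopropylcarbamoyl and thiophen-2-yl occur together in compound 4, but this single set of four compounds gives no reason for that and no general rule for the series.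

Left open is whether the rise would persist with a longer chain such as propyl, or with tert-butyl, in place of the isopropyl group, or with phenyl in place of thiophen-2-yl. Also open, from the compounds shown here alone, is how potent compound 4 is, as its reading gives the size of the inhibition at a single tested concentration and not a potency.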